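Acetamido in Place of Fluoro: Two Matched Pairs

The source may report more compounds than this note shows. Statements on the series, on what has been measured and on what is new or still open speak of the compounds shown alone.

Three compounds of this set have been examined in an ADME assay on L02 cells (Homo sapiens) for cytotoxicity, read by MTT assay, with a stated time of 24 h; on this read-out higher numbers stand for weaker inhibition and lower numbers for stronger inhibition. Compound 1 `O=C1/C(=C/c2cccc([N+](=O)[O-])c2)CN(S(=O)(=O)c2ccc(F)cc2)C/C1=C\c1cccc([N+](=O)[O-])c1` gives 15500 nM. Compound 3 `CC(=O)Nc1ccc(S(=O)(=O)N2C/C(=C\c3cccc([N+](=O)[O-])c3)C(=O)/C(=C/c3cccc([N+](=O)[O-])c3)C2)cc1` differs from compound 1 by acetamido in place of fluoro on an aromatic carbon and in this assay compound 3 gives 15800 nM, so that the step of a 1.0-fold higher number from compound 1 to compound 3 (0.01 log units; within the scatter). Compound 2 `COc1cc(/C=C2\CN(S(=O)(=O)c3ccc(F)cc3)C/C(=C\c3cc(OC)c(OC)c(OC)c3)C2=O)cc(OC)c1OC` is built on a different core, and the difference between the two cores is not broken down here; in this assay compound 2 gives 12100 nM. The values of compound 1, compound 2 and compound 3 all lie within the usual scatter of one another, so no order among them can be read from these numbers.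

Compound 4 `COc1cc(/C=C2\CN(S(=O)(=O)c3ccc(NC(C)=O)cc3)C/C(=C\c3cc(OC)c(OC)c(OC)c3)C2=O)cc(OC)c1OC` has not yet been measured. It differs from compound 2 by acetamido in place of fluoro on an aromatic carbon, which is the same change, at the same kind of place, as that made from compound 1 to compound 3. Compound 4 is expected to show a 1.0-fold higher number from compound 2 to compound 4 (0.01 log units; within the scatter) in this assay because the same change gave a 1.0-fold higher number from compound 1 to compound 3 (0.01 log units; within the scatter). Compound 4 is therefore estimated at 12300 nM, with a range from 6000 nM to 25000 nM.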

Compound 4, half-maximal inhibitory concentration: 13600 nM
Compound 4: the middle estimate sits 1.1-fold (0.04 log units) below what was measured; measured number inside the range.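

In this assay, the change from 4-fluorophenyl to 4-acetamidophenyl gives a 1.1-fold higher number from compound 2 to compound 4 (0.05 log units; within the scatter), a step that cannot be told from repeated measurement of one compound. Set beside the earlier step, the change behaves alike on the two cores, with no difference that the data can resolve: the same change on two cores in this assay, a 1.0-fold higher number (0.01 log units; within the scatter) from compound 1 to compound 3 and a 1.1-fold higher number (0.05 log units; within the scatter) from compound 2 to compound 4, 1.1-fold (0.04 log units) apart, within the scatter of two such steps. This shows that, on these two cores, fluoro can be exchanged for acetamido with no visible effect on the read-out, but it does not show that the change carries a real effect of any size from one core to another, and two cores cannot speak for the whole series.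

The compounds shown hold only fluoro or acetamido at this place, so it remains open how an amine, a carboxylic acid or a longer chain would read there. From the compounds shown here alone, it also remains open whether the step would stay this small on a core with aromatic groups other than those of compound 1 and compound 2.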